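A few compounds are considered here, and "the series" means these few. Any claim that something is new, unique, unknown or untested is made for them only; others in the source may bear on it.

Compound 3 `COc1ccc(C(=O)/C=C/c2cc(-c3cc(OC)c(OC)c(OC)c3)n[nH]2)cc1OC` gives 6320 nM in a functional assay on MDA-MB-231 cells (Homo sapiens) for inhibition, read by sulforhodamine B assay, with a stated time of 48 h (a lower number here means that less compound is tolerated, a higher number that more compound is tolerated), the lowest of the two numbers in view. Its nearest neighbour is compound 1 `COc1cc(-c2cc(/C=C/C(=O)c3ccc(N)cc3)[nH]n2)cc(OC)c1OC`, which gives 47500 nM in this assay. Compound 2 `COc1cc(-c2cc(/C=C/C(=O)c3ccc(Cl)c(Cl)c3)[nH]n2)cc(OC)c1OC` reaches only the limit of this assay, > 100000 nM, so for it there is no number. The three differ only in the aryl group on the carbonyl carbon, and every step among them moves the reading beyond the scatter: a 7.5-fold lower number from compound 1 to compound 3 (0.88 log units; beyond the scatter), an at least 15-fold lower number from compound 2 to compound 3 (1.19 log units; beyond the scatter) and an at least 2.1-fold higher number from compound 1 to compound 2 (0.32 log units; beyond the scatter). Compound 4 `COc1ccc(C(=O)/C=C/c2cc(-c3cc(OC)c(OC)c(OC)c3)n[nH]2)cc1` differs from compound 3 by a smaller change: hydrogen in place of methoxy on an aromatic carbon. For the measured compounds named here, none of the measured steps removes a single methoxy; each exchanges the whole ring substituent, and the largest of them, an at least 15-fold lower number from compound 2 to compound 3 (1.19 log units; beyond the scatter), ends at the dimethoxy pattern of compound 3. Loss of one of those two methoxy groups is therefore expected to cost something, but less than an exchange of the whole pattern did, so a modest rise in the number is expected, a 1.6-fold higher number from compound 3 to compound 4 (0.20 log units; within the scatter). For compound 4 the estimate in this assay is 10000 nM, with a range from 4000 nM to 25000 nM.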

Compound 4, concentration lethal to 50% of the cells: > 100000 nM
Compound 4: no number, only a limit; the forecaster's own chance of this, stated with the estimate: 3%; middle value at least 10-fold (1.00 log units) away from the limit.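

In this assay compound 4 gives > 100000 nM, which is a limit and not a number. The earlier steps shown here exchanged whole ring substituents, whereas this one removes only the methoxy ortho to a methoxy group, and that single loss, 3,4-dimethoxyphenyl to 4-methoxyphenyl, is already a large step, with an at least 15-fold higher number from compound 3 to compound 4 (1.19 log units; beyond the scatter), so the methoxy that remains on the ring does not preserve the reading of compound 3. Nor does that remaining methoxy match the amino group of compound 1, as methoxy in place of amino gives an at least 2.1-fold higher number from compound 1 to compound 4 (0.32 log units; beyond the scatter), so the lower readings here belong to the dimethoxy pattern of compound 3 and, at a higher number, to the amino group of compound 1, while a single methoxy gives no reading within the range.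

On these data alone, the step between compound 2 and compound 4 cannot be read, and the full size of the other steps to these two compounds stays open, because the readings stop at a limit: the limit of > 100000 nM in this assay, at which 2 of the 4 values shown sit. Also open is whether a hydroxy group, an ethoxy group or a fluorine in the place of the lost methoxy would keep the reading of compound 3 or lose it as hydrogen does.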